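This account rests on a few compounds, and the source may have more. Where it says the series, first, only, none or still open, it means among the compounds named here.

Among the measured compounds shown here, the three compounds measured so far share one core and differ only in what sits on a carbonyl carbon whose other neighbour is an amide-type nitrogen. Compound 1 `COc1cc(Cl)cc(-c2nn(-c3cccc(NC(=O)c4ccc(Cl)c(Cl)c4)c3)cc2-c2ccncc2)c1` carries 3,4-dichlorophenyl on that carbonyl carbon, and in a functional assay on Hs-578T cells (Homo sapiens) for inhibition, read by sulforhodamine B assay, with a stated time of 48 h, tested at 10 uM (on this read-out lower numbers stand for a stronger effect and higher numbers for a weaker effect at the one concentration tested), compound 1 gives 63.6%. Compound 2 `COc1cc(Cl)cc(-c2nn(-c3cccc(NC(=O)Nc4ccc(Cl)c(Cl)c4)c3)cc2-c2ccncc2)c1` carries (3,4-dichlorophenyl)amino there instead, and compound 2 gives 28.5%. Compound 3 `COc1cc(Cl)cc(-c2nn(-c3cccc(NC(=O)Nc4cccc(C(F)(F)F)c4)c3)cc2-c2ccncc2)c1` carries (3-(trifluoromethyl)phenyl)amino there, and compound 3 gives 23.2%. Compound 3 thus has the lowest of the three numbers, but its value and that of compound 2 lie within the usual scatter of each other, so no order between those two can be claimed; only compound 1 stands clearly apart. The measured steps were a number 35.1 percentage points lower from compound 1 to compound 2 (beyond the scatter), a number 40.4 percentage points lower from compound 1 to compound 3 (beyond the scatter) and a number 5.3 percentage points lower from compound 2 to compound 3 (within the scatter).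

Compound 4 `COc1cc(Cl)cc(-c2nn(-c3cccc(NC(=O)c4cccc(C(F)(F)F)c4)c3)cc2-c2ccncc2)c1` has not yet been measured. It differs from compound 3 by 3-(trifluoromethyl)phenyl in place of (3-(trifluoromethyl)phenyl)amino on a carbonyl carbon. The same kind of change, taken in the opposite direction, separates compound 1 from compound 2, where the result was a number 35.1 percentage points lower from compound 1 to compound 2 (beyond the scatter). A rise of roughly that size is therefore expected here, and compound 4 is estimated to give 60%, with a likely range from 42% to 78%; the expected step is a number 36.8 percentage points higher from compound 3 to compound 4 (beyond the scatter).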

Compound 4, a percentage reported as activity, at one concentration (the size of the read-out at that concentration, not a potency): 62.2%
Estimate against measurement, compound 4: 2.2 percentage points below, and the stated range covers the measured number.
By their numbers in this assay, from the lowest: compounds 3 and 2 (each within the scatter of the next); then compounds 4 and 1 (each within the scatter of the next).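

In this assay the large gap between the amide and the urea-type compounds now appears with a second aryl group, since the loss of the amino nitrogen gives a number 39 percentage points higher from compound 3 to compound 4 (beyond the scatter) and matches the size of the change seen in the 3,4-dichlorophenyl pair. The step of a number 33.7 percentage points higher from compound 2 to compound 4 (beyond the scatter) points the same way, although it also swaps the aryl group. Among the compounds shown here, without the amino nitrogen the two aryl groups give a number 1.4 percentage points lower from compound 1 to compound 4 (within the scatter) and so cannot be told apart, just as they could not with it, which means that across these four compounds the presence of that nitrogen on the carbonyl carbon sorts the numbers into two groups, with no compound going against this.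

No measurement at hand explains this gap between the two groups. Going by these compounds, it also remains open whether the nitrogen itself matters or simply the extra atom in that place, a question that a methylene group in place of the amino nitrogen could help to answer.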